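Swapping Chloro for Methyl on a Shared Core

The compounds below may be only part of what the source reports. "The series", "measured", "known", "first", "only" and "open" are said of these compounds alone.

Compound 2 `Clc1ccc(-c2csc(N/N=C/c3cccs3)n2)cc1` gives the largest of the three numbers recorded in a functional assay, read by spectrophotometry, with a stated time of 15 min, tested at 60 ug/mL; a higher number here means a stronger effect of the compound at the concentration tested, a lower number a weaker effect: compound 2 gives 85.2%. Compound 1 `COC(=O)c1cc(-c2csc(N/N=C/c3cccs3)n2)ccc1OCc1ccccc1` stands within the scatter of that number, because in this assay compound 1 gives 84.4%, so no order between these two can be claimed. Compound 3 `COC(=O)c1cc(-c2csc(N/N=C/c3ccc(Cl)cc3Cl)n2)ccc1OCc1ccccc1` lies further off, as in this assay compound 3 gives 66.3%. Going by the values given here, the only step measured between two compounds that differ in one place is a number 18.1 percentage points lower from compound 1 to compound 3 (beyond the scatter), and that exchange sits on a different part of the molecule.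

Compound 4 `Cc1ccc(-c2csc(N/N=C/c3cccs3)n2)cc1` differs from compound 2 in one place: methyl in place of chloro on an aromatic carbon. Among the compounds with values here, no measured step bears on this particular exchange, so there is no basis for expecting a change in this assay beyond the scatter, in either direction. The expected step, a number 3.2 percentage points lower from compound 2 to compound 4 (within the scatter), is therefore small. Compound 4 is estimated to give 82% in this assay, with a likely range from 68% to 93%.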

Compound 4, a percentage reported as inhibition, at one concentration (the size of the read-out at that concentration, not a potency): 84.4%
For compound 4 the middle estimate is 2.4 percentage points below the measured one; the range from low to high includes it.
By their numbers in this assay, from the lowest: compound 3; then compounds 1, 4 and 2 (each within the scatter of the next).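

Exchanging chloro for methyl on an aromatic carbon, para to a large group, gives a number 0.8 percentage points lower from compound 2 to compound 4 (within the scatter) in this assay. Going by these compounds alone, this is the first measured step at this position, and the two groups cannot be told apart here, so the effect at the tested concentration is kept with either one in place. Within the data shown here, it rests on a single pair of compounds, so it describes only this exchange, and nothing available explains why the two groups read alike.

From the compounds shown here alone, whether an amine, a carboxylic acid or a longer chain such as propyl at this same position would also leave the read-out in place remains open. Also open, going by these compounds, is whether the chloro-to-methyl exchange would read the same on the core of compound 1.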